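The source may report more compounds than this note shows. Statements on the series, on what has been measured and on what is new or still open speak of the compounds shown alone.

Of the compounds shown here, two have been measured in a functional assay on CHO cells (Cricetulus griseus) for cytotoxicity; on this read-out higher numbers stand for weaker inhibition and lower numbers for stronger inhibition. Compound 1 (`CN(Cc1cnc2ncncc2n1)c1ccc(C(=O)N[C@@H](CCC(=O)O)C(=O)O)cc1`) gives 5 nM and compound 2 (`CN(Cc1cnc2ncncc2n1)c1ccc(C(=O)N[C@@H](CCC(=O)OCOC(=O)C(C)(C)C)C(=O)OCOC(=O)C(C)(C)C)cc1`) gives 9 nM. These two values lie within the usual scatter of each other, so compound 1 stands level with compound 2 on the numbers available. Compound 3 (`CN(Cc1cnc2ncncc2n1)c1ccc(C(=O)N[C@@H](CCC(=O)NC(CCC(=O)O)C(=O)O)C(=O)O)cc1`) keeps the core of compound 1 but carries (1,3-dicarboxypropyl)amino in place of hydroxy on a carbonyl carbon whose other neighbour is a saturated chain carbon ((1,3-dicarboxypropyl)amino in place of hydroxy on a carbonyl carbon). Within the data shown here, no measured step shows what this change does, so the expectation is tentative: a moderate move towards a higher number in this assay, which would mean weaker inhibition. The expected change is a 6.0-fold higher number from compound 1 to compound 3 (0.78 log units; beyond the scatter). For compound 3 the estimated value is 30 nM, with an expected range of 6 nM to 200 nM.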

Compound 3, half-maximal inhibitory concentration: 3 nM
For compound 3 the middle estimate is 10-fold (1.00 log units) above the measured one; measured number below the stated range.
By their numbers in this assay, from the lowest: compounds 3, 1 and 2 (each within the scatter of the next, the first and the last beyond it).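

In this assay, (1,3-dicarboxypropyl)amino in place of hydroxy on a carbonyl carbon gives a 1.7-fold lower number from compound 1 to compound 3 (0.22 log units; within the scatter). Among these compounds, this position therefore accepts a group of 10 heavy atoms in place of 1 with no change in the read-out beyond the scatter, something compounds 1 and 2 alone could not show, as no single-place step linked them. Nothing measured here speaks to the reason for this result.

From the compounds shown here alone, it remains open whether a simple amine or a longer chain bearing further carboxylic acid groups on the same carbonyl carbon would also stay within the scatter of compound 1. A single step also cannot show how much larger the group can become before the number moves.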